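A Bromo Substituent on the Phenyl Ring of Compound 3

The source may report more compounds than this note shows. Statements on the series, on what has been measured and on what is new or still open speak of the compounds shown alone.

Compound 1, `c1ccc(C2=NN(C3=NC(c4ccccc4)CS3)C(c3cccc4ccccc34)C2)cc1`, gives 14300 nM in a functional assay on BGC-823 cells (Homo sapiens) for inhibition, read by CCK-8 assay, with a stated time of 48 h; a higher number here means a weaker inhibitor, a lower number a stronger inhibitor.
Compound 2, `COc1ccc(C2=NN(C3=NC(c4ccccc4)CS3)C(c3ccc4ccccc4c3)C2)cc1`, gives 7250 nM in this assay.
Compound 3, `c1ccc(C2=NN(C3=NC(c4ccccc4)CS3)C(c3ccc4ccccc4c3)C2)cc1`, gives 9620 nM in this assay.

Compound 3 stands second highest of the three numbers. The nearer step to it is a 1.3-fold higher number from compound 2 to compound 3 (0.12 log units; within the scatter), and the further one is a 1.5-fold lower number from compound 1 to compound 3 (0.17 log units; within the scatter); both lie within the scatter, so the three compounds cannot be told apart on these numbers.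

Compound 4, `Brc1ccc(C2=NN(C3=NC(c4ccccc4)CS3)C(c3ccc4ccccc4c3)C2)cc1`, differs from compound 3 by bromo in place of hydrogen on an aromatic carbon. Going by the values given here, the only measured step that touches this phenyl ring is a 1.3-fold higher number from compound 2 to compound 3 (0.12 log units; within the scatter), which stayed within the scatter. Among the compounds with values here, no measured pair sets bromo against hydrogen at this place. On that basis no step beyond the scatter is expected in this assay. Compound 4 is therefore estimated at 8500 nM, with a range from 3000 nM to 25000 nM, which means an expected step of a 1.1-fold lower number from compound 3 to compound 4 (0.05 log units; within the scatter).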

Compound 4, half-maximal inhibitory concentration: 13000 nM
For compound 4 the middle estimate is 1.5-fold (0.18 log units) below the measured one, within the range that was stated.
By their numbers in this assay, from the lowest: compounds 2, 3, 4 and 1 (each within the scatter of the next).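

In this assay, going by these compounds alone, the change from phenyl to 4-bromophenyl gives a 1.4-fold higher number from compound 3 to compound 4 (0.13 log units; within the scatter) and so supplies the first measured pair of bromo against hydrogen at this place. Setting bromo against methoxy at the same place gives a 1.8-fold higher number from compound 2 to compound 4 (0.25 log units; within the scatter) and likewise leaves the compounds indistinguishable on these numbers. No evidence is available to explain these results.

The compounds shown leave open whether an amine, a carboxylic acid or a longer chain at this place would produce a step beyond the scatter.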